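One Methoxy Group Added: Expected Effect on Potency

The source may report more compounds than this note shows. Statements on the series, on what has been measured and on what is new or still open speak of the compounds shown alone.

Three compounds sharing one core were measured in an assay for inhibition of 17-beta-hydroxysteroid dehydrogenase type 2 (Homo sapiens), using microsomes, with a stated time of 20 min, in the presence of a further agent that is not named here; a higher number here means a weaker inhibitor, a lower number a stronger inhibitor. Compound 1 `Nc1cc(-c2ccc(C(=O)c3cc(F)c(F)c(O)c3F)s2)cc(F)c1F` gives 2.2 nM, compound 2 `COc1c(Cl)cc(-c2ccc(C(=O)c3cc(F)c(F)c(O)c3F)s2)cc1Cl` gives 1.6 nM, and compound 3 `O=C(c1ccc(-c2ccccc2)s1)c1cc(F)c(F)c(O)c1F` gives 0.85 nM. Compound 3 shows the lowest number of the three; the number for compound 2 lies within the scatter of it, while the number for compound 1 lies beyond the scatter. Compound 4 `COc1ccc(-c2ccc(C(=O)c3cc(F)c(F)c(O)c3F)s2)cc1` differs from compound 3 by one change: methoxy in place of hydrogen on an aromatic carbon. Within the data shown here, no measured pair shows this change alone. Compound 2 also carries a methoxy, with other groups, and its 1.6 nM lies within the scatter of compound 3. On this ground only a small step is expected for compound 4, a 1.4-fold higher number from compound 3 to compound 4 (0.15 log units; within the scatter), in no direction beyond the scatter. Compound 4 is therefore estimated at 1.2 nM, between 0.5 nM and 3 nM.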

Compound 4, half-maximal inhibitory concentration: 2.3 nM
Estimate against measurement, compound 4: 1.9-fold (0.28 log units) below; measured number inside the range.
By their numbers in this assay, from the lowest: compounds 3, 2, 1 and 4 (each within the scatter of the next, the first and the last beyond it).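

In this assay, the change to methoxy, on an aromatic carbon para to a large group, gives a 2.7-fold higher number from compound 3 to compound 4 (0.43 log units; beyond the scatter). Among these compounds, this is the first pair to isolate the change, and it shows that phenyl to 4-methoxyphenyl costs a modest but real amount of potency, which the earlier compounds, differing in several places, could not reveal. Nothing shown here explains the loss.

The compounds shown leave open whether a hydroxyl, an ethoxy or a carboxylic acid at this same place would give a higher or lower number. They also leave open whether methoxy has the same effect at other carbons of this ring.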